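Fluorine Position on the Benzyl Group and Liver Cell Toxicity

A few compounds are considered here, and "the series" means these few. Any claim that something is new, unique, unknown or untested is made for them only; others in the source may bear on it.

Compound 1 `CC(C)Cc1nn(-c2nccs2)cc1C(=O)NCc1ccccc1F` and compound 2 `CCOC(=O)c1cn(-c2ccc(F)cc2)nc1CC(C)C` were both examined in a toxicity assay on HepG2 2.2.15 cells (Homo sapiens) for cytotoxicity, read by CCK-8 assay, with a stated time of 8 days; on this read-out higher numbers stand for lower toxicity in this test and lower numbers for higher toxicity in this test. In this assay compound 1 gives > 100000 nM, which is a limit of the assay rather than a measured number. In this assay compound 2 likewise gives > 100000 nM, also a limit. Compound 1 therefore stands at the limit of > 100000 nM in this assay, at which 2 of the 2 values shown sit, so no ordering of the two compounds is possible from these readings. Compound 3 `CC(C)Cc1nn(-c2nccs2)cc1C(=O)NCc1cccc(F)c1` has not yet been tested; it differs from compound 1 by 3-fluorophenyl in place of 2-fluorophenyl on a saturated chain carbon bound to an amide-type nitrogen. For the measured compounds named here, no measured step between two compounds is available here, so the only guidance is the shared limit. The step is expected to be a number no higher from compound 1 to compound 3 (the limit leaves the size open), no larger than the usual scatter and with no direction favoured. Compound 3 is accordingly expected to give about 100000 nM in this assay, within an estimated range of 50000 nM to 200000 nM, and most likely to be reported again only as a limit.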

Compound 3, half-maximal cytotoxic concentration: > 100000 nM
Compound 3 gave a limit, no number; the forecaster's own chance of this, stated with the estimate: 85%; the middle value lies on the limit itself.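

No step can be read between compound 1 and compound 3, as each reading is only a limit of the assay: the limit of > 100000 nM in this assay, at which 3 of the 3 values shown sit.

The compounds shown leave open whether 3-fluorobenzyl in place of 2-fluorobenzyl changes the toxicity at all, and how far either compound lies from that limit.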